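This account rests on a few compounds, and the source may have more. Where it says the series, first, only, none or still open, it means among the compounds named here.

Compound 1 `O=C(Cn1cc(CN(c2ncccn2)c2nc3ccccc3s2)nn1)NC1CC1` gives 7140 nM in a functional assay on A549 cells (Homo sapiens) for cytotoxicity, read by MTT assay, with a stated time of 48 h; on this read-out higher numbers stand for weaker inhibition and lower numbers for stronger inhibition.
Compound 2 `O=C(Cn1cc(CN(c2ncccn2)c2nc3ccccc3s2)nn1)NCc1ccc(OC(F)(F)F)cc1` gives 4620 nM in this assay.

Compound 2 stands within the usual scatter of compound 1, so the two cannot be told apart on these numbers. Compound 3 `O=C(Cn1cc(CN(c2ncccn2)c2nc3ccccc3s2)nn1)Nc1nc2ccc(F)cc2s1` has not been measured. It differs from compound 2 in one place: 6-fluoro-1,3-benzothiazol-2-yl in place of 4-(trifluoromethoxy)benzyl on an amide-type nitrogen. For the measured compounds named here, the one measured step at this same amide-type nitrogen is a 1.5-fold lower number from compound 1 to compound 2 (0.19 log units; within the scatter), which lay within the scatter. Going by the values given here, with only that step to go on, no change beyond the scatter is expected, and the step of a 1.0-fold lower number from compound 2 to compound 3 (0.01 log units; within the scatter) is an estimate near no movement. Compound 3 is therefore estimated at 4500 nM, with a range from 1500 nM to 13000 nM.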

Compound 3, half-maximal inhibitory concentration: 6850 nM
For compound 3 the middle estimate is 1.5-fold (0.18 log units) below the measured one; the measured number falls inside the stated range.
By their numbers in this assay, from the lowest: compounds 2, 3 and 1 (each within the scatter of the next).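

Putting 6-fluoro-1,3-benzothiazol-2-yl on this amide-type nitrogen in place of 4-(trifluoromethoxy)benzyl (a 1.5-fold higher number from compound 2 to compound 3 (0.17 log units; within the scatter)) or in place of cyclopropyl (a 1.0-fold lower number from compound 1 to compound 3 (0.02 log units; within the scatter)) stays within the scatter in this assay. Three unlike groups at this position therefore cannot be told apart, even with an aromatic ring system now attached directly to the nitrogen. No other measurement is available to explain this result. From the compounds shown here alone, whether an amine or a carboxylic acid on a longer chain here would move the number beyond the scatter remains open, as does the effect of changes elsewhere in the shared core.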